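A few compounds are considered here, and "the series" means these few. Any claim that something is new, unique, unknown or untested is made for them only; others in the source may bear on it.

Measured in a functional assay on HeLa cells (Homo sapiens) for cytotoxicity, read by MTT assay, with a stated time of 24 h; a lower number here means a stronger inhibitor, a higher number a weaker inhibitor:
compound 1, `COc1cc(/C=C2\CN(C)C/C(=C\c3ccc(Br)cc3)C2=O)cc(OC)c1`, gives 5900 nM
compound 2, `COc1cc(/C=C2\CN(C)C/C(=C\c3ccc(Cl)cc3Cl)C2=O)cc(OC)c1`, gives 7760 nM
compound 3, `COc1cc(/C=C2\CN(C)C/C(=C\c3ccc(Br)cc3)C2=O)cc(OC)c1OC`, gives 11900 nM
Not yet measured: compound 4, `COc1cc(/C=C2\CN(C)C/C(=C\c3ccc(Cl)cc3Cl)C2=O)cc(OC)c1OC`.

All three measured numbers sit close together, and neither of the two single-point steps between them leaves the usual scatter. The change from compound 1 to compound 2 is 2,4-dichlorophenyl in place of 4-bromophenyl on a double-bonded chain carbon bound to a double-bonded ring carbon; the step it made is a 1.3-fold higher number from compound 1 to compound 2 (0.12 log units; within the scatter). The cores differ by methoxy in place of hydrogen on an aromatic carbon, and that step is a 2.0-fold higher number from compound 1 to compound 3 (0.30 log units; within the scatter). Compound 2 and compound 3 are not connected by a single-point step here; their two values simply stand close to each other.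

Compound 4 stands to compound 3 as compound 2 stands to compound 1. The change is 2,4-dichlorophenyl in place of 4-bromophenyl on a double-bonded chain carbon bound to a double-bonded ring carbon, the same change at the same place as the one already measured on the other core, and the two cores differ only by the methoxy told above. Given that the earlier step was within the scatter, the step from compound 3 to compound 4 is expected to be small as well, estimated as a 1.3-fold higher number from compound 3 to compound 4 (0.11 log units; within the scatter), resting on the measured step of a 1.3-fold higher number from compound 1 to compound 2 (0.12 log units; within the scatter). The starting point for this estimate is the measured value of compound 3, 11900 nM. Compound 4 is therefore expected near 15500 nM in this assay, with a plausible range of 7000 nM to 35000 nM.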

Compound 4, half-maximal inhibitory concentration: > 20000 nM
Compound 4 ended at the assay's limit (the forecaster's own chance of this, stated with the estimate: 5%); middle value at least 1.2-fold (0.11 log units) away from the limit.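

In this assay compound 4 gives > 20000 nM, which is a limit of the assay and not a number, so each step into it is only a floor: the limit of > 20000 nM in this assay, at which 1 of the 4 values shown sits.

Carrying 2,4-dichlorophenyl in place of 4-bromophenyl onto the core of compound 3 gives an at least 1.6-fold higher number from compound 3 to compound 4 (0.22 log units; that floor lies within the scatter), which does not set this step apart from the one on the core of compound 1, and does not show that the two are the same size either: the same change on two cores in this assay, a 1.3-fold higher number (0.12 log units; within the scatter) from compound 1 to compound 2 and an at least 1.6-fold higher number (0.22 log units; that floor lies within the scatter) from compound 3 to compound 4; the limit leaves it open whether they differ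

Methoxy in place of hydrogen on an aromatic carbon gives an at least 2.5-fold higher number from compound 2 to compound 4 (0.41 log units; beyond the scatter), the one step of the pair printed as beyond the scatter, but this does not show that the methoxy change behaves differently with 2,4-dichlorophenyl than with 4-bromophenyl: the same change on two cores in this assay, a 2.0-fold higher number (0.30 log units; within the scatter) from compound 1 to compound 3 and an at least 2.5-fold higher number (0.41 log units; beyond the scatter) from compound 2 to compound 4; the limit leaves it open whether they differ

The compounds shown leave open the actual size of both steps into compound 4, and with it whether either change carries over from one core to the other at the same size. They also leave open whether the picture holds when a phenyl group carrying an amine or a carboxylic acid stands in place of 4-bromophenyl or 2,4-dichlorophenyl on the shared core.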